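The source may report more compounds than this note shows. Statements on the series, on what has been measured and on what is new or still open speak of the compounds shown alone.

Compound 1 `O=S(=O)(/C=C/c1ncccc1F)c1ccc(F)cc1` and compound 2 `O=S(=O)(/C=C/c1ncccc1Cl)c1ccc(F)cc1` share one core; compound 3 `O=S(=O)(/C=C/c1ncccc1F)c1ccccc1Cl` and compound 4 `O=S(=O)(/C=C/c1ncccc1Cl)c1ccccc1Cl` share another, and the difference between the two cores is not broken down here. In an assay on U2OS cells for activation of nuclear factor erythroid 2-related factor 2 (Homo sapiens), read by beta-arrestin recruitment, with a stated time of 6 h (a lower number here means that less compound is needed, a higher number that more compound is needed for the effect), compound 1 gives 542 nM, while compound 2 gives 231 nM. That change, (chloro in place of fluoro on an aromatic carbon), made a step of a 2.3-fold lower number from compound 1 to compound 2 (0.37 log units; beyond the scatter). In this assay compound 3 gives 122 nM. Compound 4 has not yet been measured; it differs from compound 3 by chloro in place of fluoro on an aromatic carbon, the same change, at the same place, that was made from compound 1 to compound 2. Because that change gave a 2.3-fold lower number from compound 1 to compound 2 (0.37 log units; beyond the scatter), a step of about the same size, a 2.2-fold lower number from compound 3 to compound 4 (0.35 log units; beyond the scatter), is expected from compound 3 to compound 4. Compound 4 is accordingly estimated at 55 nM, likely between 25 nM and 130 nM.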

Compound 4, half-maximal effective concentration: 26 nM
For compound 4 the middle estimate is 2.1-fold (0.33 log units) above the measured one; measured number inside the range.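

In this assay chloro in place of fluoro on an aromatic carbon gave a 4.7-fold lower number from compound 3 to compound 4 (0.67 log units; beyond the scatter) and so lowered the number on this core as it did on the core of compound 1. The change carried over in direction, and the two steps cannot be told apart in size: the same change on two cores in this assay, a 2.3-fold lower number (0.37 log units; beyond the scatter) from compound 1 to compound 2 and a 4.7-fold lower number (0.67 log units; beyond the scatter) from compound 3 to compound 4, 2.0-fold (0.30 log units) apart, within the scatter of two such steps. Among these compounds, this rests on only two pairs with a single change at a single place, so it does not show that the step would carry over to any other core or that its size is fixed.

The compounds shown leave open how other groups on the same aromatic carbon, such as bromo, methyl or an amine, would behave. Going by these compounds, whether such groups would carry over between the two cores also remains open.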